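Bromo to pentyl on the aryl of compound 3

A few compounds are considered here, and "the series" means these few. Any claim that something is new, unique, unknown or untested is made for them only; others in the source may bear on it.

Compound 1 `COc1ccc(-c2cn(C/C=C3\OC(=O)C(OCc4ccccc4)=C3OCc3ccccc3)nn2)cc1` in a functional assay on MCF7 cells (Homo sapiens) for antiproliferative activity, read by MTT assay, with a stated time of 72 h (a higher number here means a weaker inhibitor, a lower number a stronger inhibitor), gives 39100 nM. Compound 2 `O=C1O/C(=C\Cn2cc(-c3cc(F)cc(F)c3)nn2)C(OCc2ccccc2)=C1OCc1ccccc1` reaches only a limit, > 100000 nM. Compound 3 `O=C1O/C(=C\Cn2cc(-c3ccc(Br)cc3)nn2)C(OCc2ccccc2)=C1OCc1ccccc1` likewise reaches only a limit, > 100000 nM. The steps of an at least 2.5-fold higher number from compound 1 to compound 2 (0.40 log units; beyond the scatter) and an at least 2.5-fold higher number from compound 1 to compound 3 (0.40 log units; beyond the scatter) both run toward weaker inhibition, and a step that the two limits leave unreadable from compound 2 to compound 3 cannot be read because of the limit of > 100000 nM in this assay, at which 2 of the 3 values shown sit. Compound 3 thus stands at the weak end of the numbers shown, with compound 2 at the same limit.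

Compound 4 `CCCCCc1ccc(-c2cn(C/C=C3\OC(=O)C(OCc4ccccc4)=C3OCc3ccccc3)nn2)cc1` differs from compound 3 by pentyl in place of bromo on an aromatic carbon. Going by the values given here, no measured step covers this exchange, so no direction is set by the data. Compound 4 is expected to remain near the same limit, a step that the limit leaves unreadable from compound 3 to compound 4 in this assay. The estimate for compound 4 is 120000 nM, between 30000 nM and 500000 nM.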

Compound 4, half-maximal inhibitory concentration: > 100000 nM
Compound 4 was reported as a limit (the forecaster's own chance of this, stated with the estimate: 65%); the middle value lies beyond the limit too.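

In this assay compound 4 gives > 100000 nM as a limit. Going by these compounds alone, the one readable step is an at least 2.5-fold higher number from compound 1 to compound 4 (0.40 log units; beyond the scatter) and it shows that pentyl, like bromo, does not keep the measurable value seen with methoxy at this place on the aryl. The steps from compound 2 and compound 3 to compound 4 cannot be read, because all three values sit at one bound: the limit of > 100000 nM in this assay, at which 3 of the 4 values shown sit.

Going by these compounds, whether an ethoxy group, an amine or a carboxylic acid at this place would return a measurable value stays open. Among the compounds shown, methoxy remains the only group with a number.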